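Nitro to dimethylamino on a sulfonate ester P2X7 antagonist

A few compounds are considered here, and "the series" means these few. Any claim that something is new, unique, unknown or untested is made for them only; others in the source may bear on it.

Compound 1, `N#Cc1cccc(S(=O)(=O)Oc2ccc(-c3cncn3C3CCN(C(=O)c4ccc([N+](=O)[O-])cc4)CC3)cc2)c1`: 45 nM
Compound 2, `CN(C)c1ccc(C(=O)N2CCC(n3cncc3-c3ccc(OS(=O)(=O)c4cccc(C#N)c4)cc3)CC2)cc1`: 32 nM
Compound 3, `O=C(NC1CC1)c1cccc(S(=O)(=O)Oc2ccc(-c3cncn3C3CCN(C(=O)c4ccc([N+](=O)[O-])cc4)CC3)cc2)c1`: 152 nM

The three measured compounds were tested in an assay on HEK293 cells for antagonist activity at P2X purinoceptor 7 (Homo sapiens), read by fluorescence, with a stated time of 2 h; on this read-out lower numbers stand for stronger inhibition and higher numbers for weaker inhibition. Compound 1 gives 45 nM, compound 2 gives 32 nM and compound 3 gives 152 nM in this assay. Compound 2 differs from compound 1 by dimethylamino in place of nitro on an aromatic carbon, and this change gave a 1.4-fold lower number from compound 1 to compound 2 (0.15 log units; within the scatter). Compound 3 differs from compound 1 by cyclopropylcarbamoyl in place of cyano on an aromatic carbon, a step of a 3.4-fold higher number from compound 1 to compound 3 (0.53 log units; beyond the scatter).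

Compound 4, `CN(C)c1ccc(C(=O)N2CCC(n3cncc3-c3ccc(OS(=O)(=O)c4cccc(C(=O)NC5CC5)c4)cc3)CC2)cc1`, has not yet been measured in this assay. It differs from compound 3 by dimethylamino in place of nitro on an aromatic carbon, the same change as that from compound 1 to compound 2, and in both pairs the place is the same word for word. Since that change gave a 1.4-fold lower number from compound 1 to compound 2 (0.15 log units; within the scatter), the step from compound 3 to compound 4 is expected to be of similar size, a 1.4-fold lower number from compound 3 to compound 4 (0.14 log units; within the scatter), a step that stays within the scatter. Compound 4 is therefore estimated at 110 nM, with a likely range from 45 nM to 270 nM.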

Compound 4, half-maximal inhibitory concentration: 0.49 nM
Compound 4: the middle estimate sits 220-fold (2.35 log units) above what was measured, and the stated range ends above it.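

In this assay, dimethylamino in place of nitro did not carry over unchanged from one core to the other, giving a 310-fold lower number from compound 3 to compound 4 (2.49 log units; beyond the scatter) on the core that bears cyclopropylcarbamoyl: the same change on two cores in this assay, a 1.4-fold lower number (0.15 log units; within the scatter) from compound 1 to compound 2 and a 310-fold lower number (2.49 log units; beyond the scatter) from compound 3 to compound 4, 220-fold (2.34 log units) apart, beyond the scatter of two such steps. Read from the other side of the same four compounds, cyclopropylcarbamoyl in place of cyano gave a 65-fold lower number from compound 2 to compound 4 (1.81 log units; beyond the scatter), which likewise departs from its earlier counterpart: the same change on two cores in this assay, a 3.4-fold higher number (0.53 log units; beyond the scatter) from compound 1 to compound 3 and a 65-fold lower number (1.81 log units; beyond the scatter) from compound 2 to compound 4, 220-fold (2.34 log units) apart, beyond the scatter of two such steps. This shows that within these four compounds the two changes do not add up independently, but it rests on a single set of four compounds and does not show why they interact or whether the same holds elsewhere in the series.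

The compounds shown leave open whether a primary amine or a methoxy group in place of dimethylamino would give a similar result on the cyclopropylcarbamoyl core. They also leave open whether another amide, such as one with a longer chain in place of cyclopropyl, would pair with dimethylamino in the same way.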